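Swapping iodo for ethoxy: what the halogen steps suggest

This account rests on a few compounds, and the source may have more. Where it says the series, first, only, none or still open, it means among the compounds named here.

In a functional assay on MOLT-4 cells (Homo sapiens) for antiproliferative activity, with a stated time of 48 h (on this read-out lower numbers stand for stronger inhibition and higher numbers for weaker inhibition), compound 1 `C=C(Br)C(=O)Nc1ccc(/C=C/C(=O)c2ccccc2)cc1` carries hydrogen at the varied place and gives 3100 nM on this read-out. Compound 2 `C=C(Br)C(=O)Nc1ccc(/C=C/C(=O)c2ccc(Cl)cc2)cc1` has chloro there and gives 810 nM in the same test. Compound 3 `C=C(Br)C(=O)Nc1ccc(/C=C/C(=O)c2ccc(I)cc2)cc1` has iodo there and gives 2800 nM in that test as well. Compound 3 therefore sits level with compound 1 and clearly above compound 2 on the numbers, which means weaker inhibition than compound 2.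

The unmeasured compound 4 `C=C(Br)C(=O)Nc1ccc(/C=C/C(=O)c2ccc(OCC)cc2)cc1` has ethoxy in place of iodo on an aromatic carbon of a six-membered aromatic ring of carbon only, para to a large group ethoxy in place of iodo on an aromatic carbon and shares the rest of its structure with compound 3.

Three measured steps at this place bear on the change: a 3.8-fold lower number from compound 1 to compound 2 (0.58 log units; beyond the scatter) and a 1.1-fold lower number from compound 1 to compound 3 (0.04 log units; within the scatter) and a 3.5-fold higher number from compound 2 to compound 3 (0.54 log units; beyond the scatter) are all that is known. So far, changes here have been modest or lost in the scatter, and no measured compound carries ethoxy. The guide is therefore the span from compound 2 at 810 nM to compound 1 at 3100 nM in this assay with compound 3 near its upper end. A small move toward a lower number is expected, not one clearly beyond the scatter. The expected change is a 1.9-fold lower number from compound 3 to compound 4 (0.27 log units; within the scatter) as an estimate only. For compound 4 the estimated value is 1500 nM with an expected range from 500 nM to 4500 nM on this read-out.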

Compound 4, half-maximal inhibitory concentration: 610 nM
The estimate for compound 4 lay 2.5-fold (0.39 log units) above the measured number, and the stated range covers the measured number.
By their numbers in this assay, from the lowest: compounds 4 and 2 (each within the scatter of the next); then compounds 3 and 1 (each within the scatter of the next).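

In this assay, for the compounds shown here, ethoxy is the first group at this place that is not a halogen, and putting it in place of iodo gives a 4.6-fold lower number from compound 3 to compound 4 (0.66 log units; beyond the scatter) in a step that carries a real change, while against the unsubstituted parent it gives a 5.1-fold lower number from compound 1 to compound 4 (0.71 log units; beyond the scatter) as well. Set against chloro it gives a 1.3-fold lower number from compound 2 to compound 4 (0.12 log units; within the scatter) and so no real difference, which means that chloro and ethoxy now both stand apart from hydrogen at this place, whereas iodo, the other halogen, does not, even though ethoxy brings three heavy atoms and chloro only one. Nothing measured here explains why these two groups read alike while iodo reads like hydrogen.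

As far as these compounds go, it remains open whether the lower number goes with the oxygen of ethoxy or with its two carbons, a question that methoxy or a plain ethyl group at the same place would help to settle. Also open, from the compounds shown here alone, is how in this assay a longer chain such as butoxy, or an amine, would read at this place on the shared core.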